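This account rests on a few compounds, and the source may have more. Where it says the series, first, only, none or still open, it means among the compounds named here.

Of the compounds shown here, two have so far been measured in a functional assay on MGC-803 cells (Homo sapiens) for inhibition, read by MTT assay, with a stated time of 72 h, tested at 10 uM; on this read-out higher numbers stand for more inhibition of growth at the one concentration tested and lower numbers for less inhibition of growth. Compound 1 `O=C(/C=C/c1ccc(Oc2ncnc3ccc(Cl)cc23)cc1)/C=C/c1cc([N+](=O)[O-])ccc1Cl` gives 86.7%. For the measured compounds named here, compound 2 `O=C(/C=C/c1ccc(Oc2ncnc3ccc(Cl)cc23)cc1)/C=C/c1c(Cl)cccc1Cl` gives 61.7%, the lowest of the two numbers; the only recorded step is a number 25 percentage points lower from compound 1 to compound 2 (beyond the scatter), a loss beyond the scatter. Compound 3 `O=C(/C=C/c1ccc(Oc2ncnc3ccc(Cl)cc23)cc1)/C=C/c1ccc(Cl)c([N+](=O)[O-])c1` differs from compound 2 by 4-chloro-3-nitrophenyl in place of 2,6-dichlorophenyl on a double-bonded chain carbon bound to a double-bonded chain carbon. Going by the values given here, the entering group again carries a chlorine and a nitro group, as the group on compound 1 does, so that single step is the only guide, and a gain of roughly that size is expected. Compound 3 is estimated at 80%, within 60% to 95%, an expected step of a number 18.3 percentage points higher from compound 2 to compound 3 (beyond the scatter).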

Compound 3, percent growth inhibition at one concentration: 66.2%
For compound 3 the middle estimate is 13.8 percentage points above the measured one, within the range that was stated.
By their numbers in this assay, from the lowest: compounds 2 and 3 (each within the scatter of the next); then compound 1.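

Carrying a chlorine and a nitro group on this ring does not by itself match compound 1: moving to 4-chloro-3-nitrophenyl gives (a number 20.5 percentage points lower from compound 1 to compound 3 (beyond the scatter)), so the arrangement of these same two groups matters here. Swapping 2,6-dichlorophenyl for 4-chloro-3-nitrophenyl gives (a number 4.5 percentage points higher from compound 2 to compound 3 (within the scatter)), so this change makes no clear difference in this assay. No supporting measurement explains either step.

Still open, as far as these compounds go, is whether the 2-chloro-5-nitrophenyl arrangement stays favourable when an amine or a carboxylic acid takes the place of the nitro group.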